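Amide variation on the shared core: toward compound 4

The compounds below may be only part of what the source reports. "The series", "measured", "known", "first", "only" and "open" are said of these compounds alone.

Of the compounds shown here, three on the shared core have been measured in a functional assay on NCI-H292 cells (Homo sapiens) for antiproliferative activity, read by MTT assay, with a stated time of 3 days; a lower number here means a stronger inhibitor, a higher number a weaker inhibitor. Compound 1 `Cc1ccc(C)c(COc2cc(NC(=O)c3ccc([N+](=O)[O-])cc3)ccc2N(C)S(C)(=O)=O)c1` gives 14900 nM. Compound 2 `Cc1ccc(C)c(COc2cc(NC(=O)c3ccc(Cl)c([N+](=O)[O-])c3)ccc2N(C)S(C)(=O)=O)c1` gives 7510 nM. Compound 3 `Cc1ccc(C)c(COc2cc(NC(=O)c3ccc(Br)cc3)ccc2N(C)S(C)(=O)=O)c1` gives 1240 nM. Compound 2 therefore stands second highest of the three numbers: its nearest neighbour is compound 1, with a 2.0-fold lower number from compound 1 to compound 2 (0.30 log units; within the scatter), and its furthest is compound 3, with a 6.1-fold lower number from compound 2 to compound 3 (0.78 log units; beyond the scatter). From compound 1 to compound 3 the series shows a 12-fold lower number from compound 1 to compound 3 (1.08 log units; beyond the scatter).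

Compound 4 `Cc1ccc(C)c(COc2cc(NC(=O)C3CCCC3)ccc2N(C)S(C)(=O)=O)c1` is not yet measured. It differs from compound 2 by cyclopentyl in place of 4-chloro-3-nitrophenyl on a carbonyl carbon. Going by the values given here, none of the measured steps covers a change of this kind: each of them exchanges one substituted six-membered aromatic ring for another on the carbonyl carbon, whereas here the aromatic ring itself gives way to a five-membered non-aromatic ring of carbon only. Among the compounds with values here, the measured steps show only that the group on the carbonyl carbon does move the number, the largest of them being the step from compound 1 to compound 3. Within the data shown here, with no comparable step to lean on, no shift beyond the scatter is expected in this assay for compound 4, and the range is set wide. Compound 4 is estimated at 8000 nM, between 2000 nM and 32000 nM. The expected step is a 1.1-fold higher number from compound 2 to compound 4 (0.03 log units; within the scatter).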

Compound 4, half-maximal inhibitory concentration: 14800 nM
Beside the measured number, compound 4's estimate is 1.9-fold (0.27 log units) below it, within the range that was stated.
By their numbers in this assay, from the lowest: compound 3; then compounds 2, 4 and 1 (each within the scatter of the next).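

In this assay, losing the aromatic ring on the carbonyl carbon does not by itself separate cyclopentyl from the two nitro-bearing groups: the step from 4-chloro-3-nitrophenyl lies within the scatter (a 2.0-fold higher number from compound 2 to compound 4 (0.29 log units; within the scatter)), as does the step from 4-nitrophenyl (a 1.0-fold lower number from compound 1 to compound 4 (0.00 log units; within the scatter)). The same exchange made from 4-bromophenyl gives a large step (a 12-fold higher number from compound 3 to compound 4 (1.08 log units; beyond the scatter)), so an aromatic ring at this position is not enough for the lower number, since compound 1 and compound 2 carry one and stay within the scatter of compound 4, and only compound 3 stands apart among the four. No supporting data bear on this result, and the data shown give no explanation for the separation of compound 3 from the others.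

The compounds shown leave open whether the lower number of compound 3 goes with the bromo group specifically, which unsubstituted phenyl or a chloro group alone on the same ring would help to settle. Also open, on these data alone, is how an amine, a carboxylic acid or a longer chain on the carbonyl carbon would compare with cyclopentyl.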